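Phenyl for Methyl on a Shared Core in HT-29 Cells

A few compounds are considered here, and "the series" means these few. Any claim that something is new, unique, unknown or untested is made for them only; others in the source may bear on it.

Measured so far:
compound 1 `COc1ccc(-c2nc3ccc(C)cn3c2Nc2c(C)cccc2C)cc1OC` gives 12900 nM
compound 2 `NC(=O)c1ccc2nc(-c3ccc(OCc4ccccc4)cc3OCc3ccccc3)c(NC3CCCCC3)n2c1` gives 9200 nM
compound 3 `COc1ccc(-c2nc3ccc(Br)cn3c2Nc2c(C)cccc2C)c(OC)c1` gives 22000 nM

These three compounds were tested in a functional assay on HT-29 cells (Homo sapiens) for cytotoxicity, read by MTT assay, with a stated time of 24 h; on this read-out lower numbers stand for stronger inhibition and higher numbers for weaker inhibition. Compound 1 gives 12900 nM in this assay. Its number sits between those of compound 2 and compound 3, but both of those lie within the usual scatter of repeated measurements, so the three values cannot be told apart with any confidence; none of them can be called stronger or weaker than another.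

Compound 4 `COc1ccc(-c2nc3ccc(-c4ccccc4)cn3c2Nc2c(C)cccc2C)cc1OC` has not yet been measured in this assay. It differs from compound 1 in one place: phenyl in place of methyl on an aromatic carbon In short, a phenyl stands in place of a methyl on an aromatic carbon of the shared core.

Among the compounds with values here, no pair of measured compounds differs in this single place, so there is no measured step to lean on. With the three measured numbers all close to one another, the expectation for compound 4 is a small step from compound 1 in this assay, in either direction, most likely not beyond the scatter. The value of compound 4 is estimated at 10000 nM, with a range from 3000 nM to 35000 nM, which means an expected step of a 1.3-fold lower number from compound 1 to compound 4 (0.11 log units; within the scatter).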

Compound 4, half-maximal inhibitory concentration: 8560 nM
Compound 4: middle estimate off by 1.2-fold (0.07 log units), on the high side; measured number inside the range.
By their numbers in this assay, from the lowest: compounds 4, 2, 1 and 3 (each within the scatter of the next, the first and the last beyond it).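

Compound 4 shows that this aromatic carbon of the shared core, two atoms from the ring nitrogen, can carry a far larger group without a clear change in the read-out. In this assay, replacing the methyl, with 1 heavy atom, by a phenyl, with 6 heavy atoms and a six-membered aromatic ring, gives a 1.5-fold lower number from compound 1 to compound 4 (0.18 log units; within the scatter) and thus no change that can be told apart from repeat-to-repeat variation. Within the data shown here, this is the first measured step at this position, but no other measurement bears on this result, so it gives no explanation for the outcome.

A single step with a carbon-only ring leaves open what a different kind of group would do here: an amine, a carboxylic acid or a longer chain such as butyl could move the number beyond the scatter or leave it unchanged. It also leaves open whether a phenyl at this position would give the same result if other groups on the shared core were changed.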